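A few compounds are considered here, and "the series" means these few. Any claim that something is new, unique, unknown or untested is made for them only; others in the source may bear on it.

Working notes on the series

The three measured compounds share one core and differ only in the group carried on the saturated chain bound to an aromatic nitrogen: compound 1 `CCCCn1nc(-c2cccnc2)c2ccccc2c1=O`, compound 2 `O=c1c2ccccc2c(-c2cccnc2)nn1CC1CCCCC1` and compound 3 `O=c1c2ccccc2c(-c2cccnc2)nn1CCSc1nccs1`. In an assay on isolated protein (Oryctolagus cuniculus) with Thromboxane-A synthase (Homo sapiens) as the target, tested at 1 uM (a lower number here means less inhibition, a higher number more inhibition at the concentration tested (going by the name of the read-out)), compound 1 gives 91%, compound 2 gives 98% and compound 3 gives 97%. Compound 3 thus holds the second highest of the three numbers; its nearest neighbour is compound 2 and its furthest is compound 1, and both gaps lie within the scatter. The steps confirm this: a number 7 percentage points higher from compound 1 to compound 2 (within the scatter), a number 6 percentage points higher from compound 1 to compound 3 (within the scatter) and a number 1 percentage points lower from compound 2 to compound 3 (within the scatter). Every change on that chain so far has left the read-out essentially unchanged at a high level.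

Compound 4 `CC(C)NC(=O)CCCn1nc(-c2cccnc2)c2ccccc2c1=O` is the next member. Its change against compound 3 is (isopropylcarbamoyl)methyl in place of (1,3-thiazol-2-yl)sulfanyl on a saturated chain carbon, two bonds along the chain from an aromatic nitrogen. Among the compounds with values here, the steps that bear on it are those at the same chain position, from compound 1 to compound 3 and from compound 2 to compound 3, both within the scatter, though neither of them brought in a hydrogen-bond donor or an acyclic group of this kind. On that basis no step beyond the scatter is expected, with the estimated step being a number 7 percentage points lower from compound 3 to compound 4 (within the scatter). Compound 4 is therefore expected to give about 90%, in a range from 74% to 99%.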

Compound 4, a percentage reported as inhibition, at one concentration (the size of the read-out at that concentration, not a potency): 89%
Compound 4: the middle estimate sits 1 percentage points above what was measured; the range from low to high includes it.
By their numbers in this assay, from the lowest: compounds 4, 1, 3 and 2 (each within the scatter of the next).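

Among the four compounds, only compound 4 carries a carbonyl and a hydrogen-bond donor on the chain, and in this assay this change still gives only steps within the scatter: a number 8 percentage points lower from compound 3 to compound 4 (within the scatter) and a number 9 percentage points lower from compound 2 to compound 4 (within the scatter) as well as a number 2 percentage points lower from compound 1 to compound 4 (within the scatter) for the isopropylcarbamoyl end group alone. Within these compounds, the position therefore accepts an open-chain amide as well as the cyclohexyl and (1,3-thiazol-2-yl)sulfanyl groups, with no ring needed on the chain to keep the read-out in the same band. Nothing among the data bears on why such different groups give readings this close.

A single concentration gives the size of the inhibition and not a potency, so the four compounds may or may not separate at lower concentrations, and the present numbers cannot tell which. From the compounds shown here alone, it also remains open whether the position keeps the same band with a carboxylic acid or a primary amine at the end of the chain, or with a methyl group in place of the amide hydrogen.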